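Notes on the amine substituent in the series

The compounds below may be only part of what the source reports. "The series", "measured", "known", "first", "only" and "open" are said of these compounds alone.

compound 1 `CC(C)=CCc1cc(C(=O)Nc2cc3ccc(OCCC4CCCCN4)c(C)c3oc2=O)ccc1O` gives 640 nM
compound 2 `CC(C)=CCc1cc(C(=O)Nc2cc3ccc(OCCCNC4CCCCC4)c(C)c3oc2=O)ccc1O` gives 660 nM

Going by the values given here, in a functional assay on SK-BR-3 cells (Homo sapiens) for antiproliferative activity (on this read-out lower numbers stand for stronger inhibition and higher numbers for weaker inhibition), compound 2 gives 660 nM and stands level, within the scatter, with compound 1 at 640 nM as the only other measured member of the series. The change to compound 3 `CC(C)=CCc1cc(C(=O)Nc2cc3ccc(OCCCNC(C)(C)c4ccccc4)c(C)c3oc2=O)ccc1O` puts 1-methyl-1-phenylethyl in place of cyclohexyl on an amine nitrogen and leaves the rest of compound 2 untouched. Among the compounds with values here, only one measured step bears on this, and only loosely: a 1.0-fold higher number from compound 1 to compound 2 (0.01 log units; within the scatter) is the sole guide. That step swaps piperidin-2-yl for (cyclohexylamino)methyl and does not bring an aromatic ring onto the amine nitrogen. Within the data shown here, no measured compound carries 1-methyl-1-phenylethyl, so the data give no direction for the change. No step beyond the scatter is therefore expected in this assay, although this expectation is weakly supported. The estimated 1.1-fold higher number from compound 2 to compound 3 (0.03 log units; within the scatter) should be read with that uncertainty in mind. For compound 3 the expected value is 700 nM with an estimated range of 280 nM to 1700 nM on current evidence.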

Compound 3, half-maximal inhibitory concentration: 960 nM
Beside the measured number, compound 3's estimate is 1.4-fold (0.14 log units) below it; low and high end bracket the measured number.
By their numbers in this assay, from the lowest: compounds 1, 2 and 3 (each within the scatter of the next).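

Working from this assay, the amine nitrogen on the saturated chain accepts 1-methyl-1-phenylethyl in place of cyclohexyl with a 1.5-fold higher number from compound 2 to compound 3 (0.16 log units; within the scatter) as the whole of the step, so this position now holds an aromatic ring and a larger substituent, 9 heavy atoms against 6, without leaving the scatter. The wider exchange reads the same way, with a 1.5-fold higher number from compound 1 to compound 3 (0.18 log units; within the scatter) for the replacement of piperidin-2-yl by ((1-methyl-1-phenylethyl)amino)methyl, and the three amine substituents shown therefore stand level within the scatter, with no compound among them going against that reading. Nothing available here gives a reason why these substituents read alike.

From the compounds shown here alone, whether this nitrogen needs a large ring-bearing substituent at all stays open, and a small group such as methyl on the amine nitrogen would address that, as would benzyl, which keeps the phenyl ring without the two methyl groups. Equally open, going by these compounds, is how far the flat profile extends to a charged or strongly polar substituent, such as a carboxylic acid on the phenyl ring, or to a longer chain between the oxygen and the amine.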